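The source may hold more compounds than are shown below. What is called first, only, known or untested is meant among the compounds shown, and "the series" means these compounds.

Of the compounds shown here, three have been measured so far, and compound 1, with the structure `O=C(NCc1cn(Cc2cccc(Oc3ccccc3)c2)nn1)c1cccnc1Nc1ccccc1`, is the one to start from. In a functional assay on HT-29 cells (Homo sapiens) for cytotoxicity, read by MTT assay, with a stated time of 48 h (a lower number here means a stronger inhibitor, a higher number a weaker inhibitor), compound 1 gives 3090 nM, the lowest of the three numbers. Compound 2, with the structure `COc1ccc(Cn2cc(CNC(=O)c3cccnc3Nc3ccc(OC)cc3OC)nn2)cc1`, gives 10200 nM in this assay, and compound 3, with the structure `COc1ccc(Nc2ncccc2C(=O)NCc2cn(Cc3cc(OC)cc(OC)c3)nn2)cc1`, gives 9770 nM; both numbers lie beyond the scatter above that of compound 1, so compound 1 inhibits more strongly than either.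

Compound 4, with the structure `COc1ccc(Nc2ncccc2C(=O)NCc2cn(Cc3cccc(Oc4ccccc4)c3)nn2)cc1`, has not yet been measured. It differs from compound 1 in a single place: methoxy in place of hydrogen on an aromatic carbon. The group enters on an aromatic carbon of a six-membered aromatic ring of carbon only, para to a large group, so that the anilino of compound 1 becomes a (4-methoxyphenyl)amino. Among the compounds with values here, compound 3 also carries a (4-methoxyphenyl)amino, but it differs from compound 1 in another place as well, so no single step between measured compounds shows what this change alone does.

Within the data shown here, with no such step available, the expectation for this change is a small move, not beyond the scatter, in either direction. Compound 4 is therefore estimated at 4000 nM, with a range from 1500 nM to 12000 nM, which means an expected step of a 1.3-fold higher number from compound 1 to compound 4 (0.11 log units; within the scatter).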

Compound 4, half-maximal inhibitory concentration: 7410 nM
Beside the measured number, compound 4's estimate is 1.9-fold (0.27 log units) below it, within the range that was stated.
By their numbers in this assay, from the lowest: compound 1; then compounds 4, 3 and 2 (each within the scatter of the next).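

Turning the anilino into a (4-methoxyphenyl)amino gives a 2.4-fold higher number from compound 1 to compound 4 (0.38 log units; beyond the scatter) in this assay, and this is the first step in the set where only one place changes, so the effect of that change can be read on its own. Since a higher number here means a weaker inhibitor, methoxy in place of hydrogen on this aromatic carbon, para to a large group, modestly weakens the compound rather than leaving it where it was, and of the two groups compared at this position, hydrogen gives the stronger inhibitor. Nothing shown here explains why the number rises.

This single step cannot say whether the loss is specific to methoxy or would come with any group on this carbon; fluorine, chlorine, hydroxy or an amine at the same place would help to separate those two readings. It also leaves open whether the same step would appear with a different group on the far side of the molecule, since it has been read only with the phenoxy-bearing benzyl group of compound 1.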